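Lengthening the Selenium-Bearing Chain Again

The source may report more compounds than this note shows. Statements on the series, on what has been measured and on what is new or still open speak of the compounds shown alone.

compound 1 `COc1ccc(N(C)c2nc(C)nc3ccccc23)cc1OCCC[Se]C#N`: 921 nM
compound 2 `COc1ccc(N(C)c2nc(C)nc3ccccc23)cc1OCC[Se]C#N`: 19 nM

Among the measured compounds shown here, in a functional assay on LoVo cells (Homo sapiens) for inhibition, read by MTT assay, with a stated time of 48 h (on this read-out lower numbers stand for stronger inhibition and higher numbers for weaker inhibition), compound 1 gives 921 nM, the higher of the two numbers so far, while compound 2 gives 19 nM. Compound 3 `COc1ccc(N(C)c2nc(C)nc3ccccc23)cc1OCCCC[Se]C#N` has not yet been measured. It differs from compound 1 by a group of 4 heavy atoms (2 carbon, 1 nitrogen, 1 selenium; no ring) in place of a group of 3 heavy atoms (1 carbon, 1 nitrogen, 1 selenium; no ring), on a saturated chain carbon, three bonds along the chain from an oxygen on an aromatic ring. For the measured compounds named here, the one measured step that bears on this change is a 48-fold lower number from compound 1 to compound 2 (1.69 log units; beyond the scatter), where the shorter chain brought a large drop in the number. Compound 3 moves in the opposite direction, lengthening the chain once more, so a further rise beyond the scatter is expected, though perhaps a smaller one: a 2.7-fold higher number from compound 1 to compound 3 (0.43 log units; beyond the scatter). Compound 3 is therefore estimated at 2500 nM, within a range from 700 nM to 9000 nM.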

Compound 3, half-maximal inhibitory concentration: 882 nM
For compound 3 the middle estimate is 2.8-fold (0.45 log units) above the measured one; the measured number falls inside the stated range.
By their numbers in this assay, from the lowest: compound 2; then compounds 3 and 1 (each within the scatter of the next).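

At this position on the saturated chain, the loss does not keep growing as the chain lengthens: in this assay there is a 1.0-fold lower number from compound 1 to compound 3 (0.02 log units; within the scatter) while there is also a 46-fold higher number from compound 2 to compound 3 (1.67 log units; beyond the scatter) for the chain of compound 2. Among these three compounds, only compound 2 stands apart, and compounds 1 and 3 cannot be told apart. No measurement shown gives a reason for this.

As far as these compounds go, whether a longer chain stays at this level remains open. So does the effect of an amine at the chain end in place of the selenium-bearing group.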